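Acyl chain length on the shared core, cytotoxicity

The compounds below may be only part of what the source reports. "The series", "measured", "known", "first", "only" and "open" are said of these compounds alone.

Measured so far:
compound 1 `CC(=O)Nc1ccn([C@@H]2CO[C@H](CO)O2)c(=O)n1` — 10700 nM
compound 2 `CCCCCCCCC(=O)Nc1ccn([C@@H]2CO[C@H](CO)O2)c(=O)n1` — 276 nM

In a functional assay on SW1573 cells (Homo sapiens) for cytotoxicity, read by sulforhodamine B assay, with a stated time of 72 h (on this read-out lower numbers stand for stronger inhibition and higher numbers for weaker inhibition), compound 2 stands lowest of the two numbers; the nearest is compound 1, whose number is higher by a 39-fold lower number from compound 1 to compound 2 (1.59 log units; beyond the scatter). Compound 3 `CCCCCCCCCCCCCCCCCCCC(=O)Nc1ccn([C@@H]2CO[C@H](CO)O2)c(=O)n1` differs from compound 2 by undecyl in place of hydrogen on a saturated chain carbon, eight bonds along the chain from a carbonyl carbon. Going by the values given here, the only step that bears on this, a 39-fold lower number from compound 1 to compound 2 (1.59 log units; beyond the scatter), also lengthened the chain on the amide and moved the number well beyond the scatter downward. A further move in the same direction, but smaller, is expected for compound 3: a 1.4-fold lower number from compound 2 to compound 3 (0.14 log units; within the scatter). Compound 3 is estimated at 200 nM, within 40 nM to 2000 nM.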

Compound 3, half-maximal inhibitory concentration: 150 nM
Estimate against measurement, compound 3: 1.3-fold (0.12 log units) above, within the range that was stated.
By their numbers in this assay, from the lowest: compounds 3 and 2 (each within the scatter of the next); then compound 1.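

In this assay, undecyl in place of hydrogen on a saturated chain carbon, eight bonds along the chain from a carbonyl carbon, gives a 1.8-fold lower number from compound 2 to compound 3 (0.26 log units; within the scatter). The large step seen with heptyl, a 39-fold lower number from compound 1 to compound 2 (1.59 log units; beyond the scatter), is therefore not repeated with this further extension, and the two longer acyl chains cannot be told apart here. No supporting data on hand account for this result.

Open, as far as these compounds go, is whether an intermediate or still longer chain departs from this level. Also open, from the compounds shown here alone, is whether an amine or a carboxylic acid on the chain preserves it.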